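3,4-Dimethoxyphenyl to 4-methoxyphenyl: a small step expected

The compounds below may be only part of what the source reports. "The series", "measured", "known", "first", "only" and "open" are said of these compounds alone.

Values in a functional assay on COLO 205 cells (Homo sapiens) for cytotoxicity, read by sulforhodamine B assay, with a stated time of 48 h; on this read-out lower numbers stand for stronger inhibition and higher numbers for weaker inhibition:
- compound 1 `COc1cc(/C=C/C(=O)/C=C/c2cccs2)ccc1OCc1cn(CCOc2cc(=O)oc3ccccc23)nn1`: 11400 nM
- compound 2 `COc1cc(/C=C/C(=O)/C=C/c2cc(OC)c(OC)c(OC)c2)ccc1OCc1cn(CCOc2cc(=O)oc3ccccc23)nn1`: 4680 nM
- compound 3 `COc1ccc(/C=C/C(=O)/C=C/c2ccc(OCc3cn(CCOc4cc(=O)oc5ccccc45)nn3)c(OC)c2)cc1OC`: 6780 nM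

Compound 3, at 6780 nM, lies within the scatter of both other compounds. The measured step to it from thiophen-2-yl is a 1.7-fold lower number from compound 1 to compound 3 (0.23 log units; within the scatter). Only compound 1 and compound 2 stand clearly apart, with a 2.4-fold lower number from compound 1 to compound 2 (0.39 log units; beyond the scatter).

The next compound is compound 4 `COc1ccc(/C=C/C(=O)/C=C/c2ccc(OCc3cn(CCOc4cc(=O)oc5ccccc45)nn3)c(OC)c2)cc1`, in which 3,4-dimethoxyphenyl becomes 4-methoxyphenyl: hydrogen in place of methoxy on an aromatic carbon. Among the measured compounds shown here, the closest precedent is the same kind of exchange, hydrogen in place of methoxy on an aromatic carbon, which turned 3,4,5-trimethoxyphenyl into 3,4-dimethoxyphenyl: a 1.4-fold higher number from compound 2 to compound 3 (0.16 log units; within the scatter). For the measured compounds named here, with only this one comparable step, no change beyond the scatter is expected in this assay, with at most a slight drift towards a higher number. The expected step is a 1.2-fold higher number from compound 3 to compound 4 (0.06 log units; within the scatter). The estimate for compound 4 is 7800 nM, with an expected range of 3800 nM to 15000 nM.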

Compound 4, half-maximal inhibitory concentration: 11300 nM
Beside the measured number, compound 4's estimate is 1.4-fold (0.16 log units) below it; measured number inside the range.
By their numbers in this assay, from the lowest: compounds 2, 3, 4 and 1 (each within the scatter of the next, the first and the last beyond it).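

Taken singly, the loss of a methoxy group stays within the scatter, with a 1.7-fold higher number from compound 3 to compound 4 (0.22 log units; within the scatter) in this assay, but going from 3,4,5-trimethoxyphenyl to 4-methoxyphenyl gives a 2.4-fold higher number from compound 2 to compound 4 (0.38 log units; beyond the scatter) and passes beyond it. 4-Methoxyphenyl and thiophen-2-yl cannot be told apart here, with a 1.0-fold lower number from compound 1 to compound 4 (0.00 log units; within the scatter) as the step between them, so the only gaps beyond the scatter separate 3,4,5-trimethoxyphenyl from these two groups. Nothing measured here explains these differences.

Still open is whether plain phenyl, or a ring carrying an amine or a carboxylic acid in place of methoxy, would fall among these numbers or away from them. As far as these compounds go, it is also open whether the same methoxy exchanges would give similar steps with a longer chain in the shared core.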